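Benzyl in Place of 2-Fluorophenyl on the Ring Nitrogen

The compounds below may be only part of what the source reports. "The series", "measured", "known", "first", "only" and "open" are said of these compounds alone.

Measured compounds:
Compound 1 `O=c1nc2oc(C3CC3)c(C#CC3CC3)c2cn1Cc1cn(-c2ccccc2F)nn1`: 49100 nM
Compound 2 `CCCCCc1ccc(C#Cc2c(-c3ccc(CCCCC)cc3)oc3nc(=O)n(Cc4cn(-c5ccc(Cl)cc5)nn4)cc23)cc1`: > 100000 nM

Of the compounds shown here, two have been measured in a functional assay on SW-620 cells (Homo sapiens) for antiproliferative activity, read by MTT assay, with a stated time of 72 h; a lower number here means a stronger inhibitor, a higher number a weaker inhibitor. Compound 1 gives 49100 nM, which is the only number shown. For compound 2 this assay gives > 100000 nM, a limit and not a number; it is the limit of > 100000 nM in this assay, at which 1 of the 2 values shown sits. No step between the two measured compounds is shown, since they differ in more than one place, and the two values say only that compound 1 has a number while compound 2 has a limit.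

Compound 3 `O=c1nc2oc(C3CC3)c(C#CC3CC3)c2cn1Cc1cn(Cc2ccccc2)nn1` is not yet measured. It differs from compound 1 in one place: benzyl in place of 2-fluorophenyl on an aromatic nitrogen. Both groups carry the same count of heavy atoms and neither brings a donor or acceptor. For the measured compounds named here, with no measured step to lean on, compound 3 is expected to stay near compound 1, with a step of a 1.0-fold higher number from compound 1 to compound 3 (0.01 log units; within the scatter) in this assay that need not exceed the scatter. Compound 3 is therefore estimated at 50000 nM, within a range from 15000 nM to 150000 nM.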

Compound 3, half-maximal inhibitory concentration: 9720 nM
The estimate for compound 3 lay 5.1-fold (0.71 log units) above the measured number; measured number below the stated range.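

In this assay, for the compounds shown here, the group on the aromatic nitrogen of the five-membered ring proves to be a position that matters: benzyl in place of 2-fluorophenyl gives a 5.1-fold lower number from compound 1 to compound 3 (0.70 log units; beyond the scatter), the first step that can be read at all. The two groups carry the same count of heavy atoms, the same six-membered aromatic ring of carbon only and no hydrogen-bond donors or acceptors, so the number at this position moves beyond the scatter even though these counts stay the same. Nothing measured here gives a reason for the step.

The single step changes two things at once, the fluorine leaves and a carbon link enters, and the compounds shown do not tell which of these goes with the lower number; an unsubstituted phenyl or a 2-phenylethyl chain on the same nitrogen would bear on that question. On these data alone, it also remains open whether the step carries over to other groups on the shared core, or whether a benzyl ring bearing fluorine or an amine would lower the number further.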